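A few compounds are considered here, and "the series" means these few. Any claim that something is new, unique, unknown or untested is made for them only; others in the source may bear on it.

In an assay on a protein complex for inhibition of CDK8/Cyclin C (Homo sapiens), with a stated time of 1 h (on this read-out higher numbers stand for weaker inhibition and lower numbers for stronger inhibition), compound 2 `CCOC(=O)/C=C/c1ccncc1-c1ccc2[nH]ccc2c1` gives 107 nM, the lowest of the three numbers recorded. Compound 1 `O=C(/C=C/c1ccncc1-c1ccc2[nH]ccc2c1)N1CCOCC1` gives 190 nM, and a 1.8-fold lower number from compound 1 to compound 2 (0.25 log units; within the scatter), so the two values stand within the scatter of each other. Compound 3 `CN1CCN(C(=O)/C=C/c2ccncc2-c2ccc(F)cc2)CC1` gives 1210 nM; it differs from compound 2 in more than one place, and the gap between the two values lies beyond the scatter. Compound 4 `CCOC(=O)/C=C/c1ccncc1-c1ccc2c(ccn2C)c1` has not yet been measured. Its difference from compound 2 is methyl in place of hydrogen on an aromatic nitrogen. Within the data shown here, no measured step touches this aromatic nitrogen: the only recorded step, a 1.8-fold lower number from compound 1 to compound 2 (0.25 log units; within the scatter), concerns the group on the carbonyl carbon and lies within the scatter. The series therefore offers no measured guidance for the change to compound 4, and any expectation rests on the structural change alone and must be held loosely. Compound 4 is expected to give about 300 nM, within a range from 80 nM to 1500 nM. Among the measured compounds shown here, this estimate means that a 2.8-fold higher number from compound 2 to compound 4 (0.45 log units; beyond the scatter) is expected, a modest rise in the number that no recorded step either supports or contradicts.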

Compound 4, half-maximal inhibitory concentration: 144 nM
Beside the measured number, compound 4's estimate is 2.1-fold (0.32 log units) above it, and the stated range covers the measured number.
By their numbers in this assay, from the lowest: compounds 2, 4 and 1 (each within the scatter of the next); then compound 3.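

In this assay, among these compounds, methyl in place of hydrogen on the aromatic nitrogen gives a 1.3-fold higher number from compound 2 to compound 4 (0.13 log units; within the scatter) as the only measured step at this position. With the ethoxy group on the carbonyl carbon held fixed, the hydrogen on this nitrogen can therefore be replaced by a single carbon without a change that stands out from the scatter. Nothing available accounts for this result. As far as these compounds go, whether a larger group on this nitrogen, such as ethyl, benzyl or a longer chain ending in an amine, would leave the number equally close remains open. Also open, from the compounds shown here alone, is whether methyl at this position would give the same outcome with the morpholin-4-yl group of compound 1 on the carbonyl carbon, or with a carboxylic acid there.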